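A few compounds are considered here, and "the series" means these few. Any claim that something is new, unique, unknown or untested is made for them only; others in the source may bear on it.

The measured compounds and their values:

Compound 1, `CC(C)n1cnc2c(Nc3ccccc3)nc(NCOCc3ccc(/C=C/C(=O)Nc4ccccc4N)cc3)nc21`, in a functional assay on NCI-H460 cells (Homo sapiens) for antiproliferative activity, read by CCK-8 assay, with a stated time of 72 h, tested at 2 uM (a higher number here means a stronger effect of the compound at the concentration tested, a lower number a weaker effect), gives 41%.
Compound 2, `CCCCn1cnc2c(NCc3ccc(C(=O)Nc4ccccc4N)cc3)nc(Cl)nc21`, in this assay gives 19.7%.
Compound 3, `CC(C)n1cnc2c(NCc3ccc(C(=O)Nc4ccccc4N)cc3)nc(Cl)nc21`, in this assay gives 54.2%.

Compound 3 and compound 2 share one core and differ in a single place: butyl in place of isopropyl on an aromatic nitrogen. That change produced a number 34.5 percentage points lower from compound 3 to compound 2 (beyond the scatter), a large step, so the longer chain on the ring nitrogen went with a clearly weaker effect in this pair.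

Compound 1 is built on a different core, and the difference between the two cores is not broken down here. Its value shows it somewhat weaker than compound 3 but clearly stronger than compound 2.

Compound 4, `CCCCn1cnc2c(Nc3ccccc3)nc(NCOCc3ccc(/C=C/C(=O)Nc4ccccc4N)cc3)nc21`, has not yet been measured. Within the data shown here, it differs from compound 1 by butyl in place of isopropyl on an aromatic nitrogen, which is the same change as the one from compound 3 to compound 2, made at the same place. Among the measured compounds shown here, the only guide to its size is that single earlier pair. Because the same change gave a number 34.5 percentage points lower from compound 3 to compound 2 (beyond the scatter), the step to compound 4 is expected to be a number 29 percentage points lower from compound 1 to compound 4 (beyond the scatter), with the caution that one pair on a different core is a thin basis.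

Compound 4 is therefore expected to give about 12%, most likely between 0% and 35%.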

Compound 4, a percentage reported as inhibition, at one concentration (the size of the read-out at that concentration, not a potency): 23.1%
The estimate for compound 4 lay 11.1 percentage points below the measured number; the measured number falls inside the stated range.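

Butyl in place of isopropyl on an aromatic nitrogen again gave a number 17.9 percentage points lower from compound 1 to compound 4 (beyond the scatter) in this assay and so ran in the same direction as it did on the core of compound 3. On both cores the butyl compound is the weaker of its pair, but the size of the drop did not carry over unchanged from one core to the other: the same change on two cores in this assay, a number 34.5 percentage points lower (beyond the scatter) from compound 3 to compound 2 and a number 17.9 percentage points lower (beyond the scatter) from compound 1 to compound 4, 16.6 percentage points apart, beyond the scatter of two such steps. This supports the direction of the change in these two pairs only; it does not explain why the size differs, and two pairs cannot show whether a third core would follow the same direction or what size of drop it would give.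

The compounds shown leave open how the effect moves with other groups on that aromatic nitrogen, such as a shorter chain like ethyl, a longer chain like hexyl, a ring like cyclopentyl, or a chain ending in an amine. They also leave open whether the difference between isopropyl and butyl holds at other concentrations or in other cell lines, and so whether it reaches beyond this single read-out.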